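A Methoxy Removal, Measured Once, Expected Again

The source may hold more compounds than are shown below. What is called first, only, known or untested is meant among the compounds shown, and "the series" means these compounds.

Of the compounds shown here, three sharing one core have been measured in an assay on HL-60 cells for inhibition of glutathione S-transferase P (Homo sapiens), read by spectrophotometry, tested at 20 uM; a higher number here means more inhibition at the concentration tested (going by the name of the read-out), a lower number less inhibition. Compound 1 `Cc1ccc2c(c1)C(=O)/C(=C/c1ccccc1)CN2CC(=O)O` gives 4.23%. Compound 2 `COc1cccc(/C=C2\CN(CC(=O)O)c3ccc(C)cc3C2=O)c1` gives 14.4%. Compound 3 `COc1cc(/C=C2\CN(CC(=O)O)c3c(C)cccc3C2=O)cc(OC)c1OC` gives 0.85%, the lowest of the three; its value lies within the scatter of compound 1 and beyond the scatter of compound 2. How the core of compound 3 differs from that of compound 2 is not broken down here.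

Between compound 2 and compound 1 the change is hydrogen in place of methoxy on an aromatic carbon, and it made a number 10.2 percentage points lower from compound 2 to compound 1 (beyond the scatter), a modest loss of inhibition.

Compound 4 `COc1cc(/C=C2\CN(CC(=O)O)c3c(C)cccc3C2=O)cc(OC)c1` has not yet been measured in this assay. It differs from compound 3 by hydrogen in place of methoxy on an aromatic carbon. Going by the values given here, this is the same kind of change as the one from compound 2 to compound 1, though not the same: in compound 1 the hydrogen stands meta to a large group, whereas in compound 4 it stands ortho to two methoxy groups and para to a large group.

Given that compound 3 already gives 0.85%, there is little room for a further loss of the size seen from compound 2 to compound 1, so the step from compound 3 to compound 4 is expected to be small, a number 2.2 percentage points higher from compound 3 to compound 4 (within the scatter). Compound 4 is therefore expected to give about 3% in this assay, between -5% and 12%.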

Compound 4, a percentage reported as inhibition, at one concentration (the size of the read-out at that concentration, not a potency): 32.3%
For compound 4 the middle estimate is 29.3 percentage points below the measured one; the whole stated range lies below it.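

In this assay, hydrogen in place of methoxy on an aromatic carbon gave a number 31.5 percentage points higher from compound 3 to compound 4 (beyond the scatter), so the earlier step predicted neither the size nor the direction of this one. Set side by side, the two cases disagree: the same change on two cores in this assay, a number 10.2 percentage points lower (beyond the scatter) from compound 2 to compound 1 and a number 31.5 percentage points higher (beyond the scatter) from compound 3 to compound 4, 41.6 percentage points apart, beyond the scatter of two such steps. This shows that, among these compounds, the effect of this change cannot simply be carried from one core to another, but it does not show what sets the two steps apart, as the pairs differ both in their core and in the groups around the changed carbon, and two steps, each read at a single concentration, give no rule.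

The compounds shown leave open whether the rise follows the core or the place of the change, ortho to two methoxy groups and para to a large group, as no pair here makes the change at the same place on both cores. Also open, on these data alone, is how a different group at that carbon, such as a hydroxyl or an amine, would compare with hydrogen and methoxy on either core.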